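Solubility notes: biaryl replacement for fluoro in compound 3

The source may report more compounds than this note shows. Statements on the series, on what has been measured and on what is new or still open speak of the compounds shown alone.

Measured so far:
compound 1 `CCOc1cc(CN2CCC(NC(=O)c3cncc(C)c3)CC2)cc(OCC)c1Cl`, a physicochemical assay for solubility, in phosphate buffer, at pH 6.5 (a higher number here means a more soluble compound, a lower number a less soluble compound), 216 ug/mL
compound 2 `CCOc1cc(CN2CCC(NC(=O)c3ccc(NC)nc3)CC2)cc(OCC)c1F`, 330 ug/mL
compound 3 `CCOc1cc(CN2CCC(NC(=O)c3cncc(C)c3)CC2)cc(OCC)c1F`, 443 ug/mL

Compound 3 gives the highest number of the three. Against compound 2 the gap is a 1.3-fold higher number from compound 2 to compound 3 (0.13 log units; within the scatter), which is within the scatter, so the two are not separated. Against compound 1 the gap is a 2.1-fold higher number from compound 1 to compound 3 (0.31 log units; beyond the scatter), a modest step beyond the scatter, where the compound with the smaller halogen gave the higher number.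

Compound 4 `CCOc1cc(CN2CCC(NC(=O)c3cncc(C)c3)CC2)cc(OCC)c1-c1ccc(OC(F)(F)F)cc1` is not yet measured. It differs from compound 3 thus: 4-(trifluoromethoxy)phenyl in place of fluoro on an aromatic carbon. Neither measured step matches this change. The halogen swap from compound 1 to compound 3 is the nearer comparison, and it was modest; the present change is far larger in what enters, so a larger step is expected, in the downward direction. The estimate for compound 4 in this assay is 30 ug/mL, with a range of 5 ug/mL to 120 ug/mL, a step of a 15-fold lower number from compound 3 to compound 4 (1.17 log units; beyond the scatter), which is expected rather than known.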

Compound 4, solubility: < 1 ug/mL
Compound 4 was reported as a limit; the forecaster's own chance of this, stated with the estimate: 10%; middle value at least 30-fold (1.47 log units) from the limit.
By their numbers in this assay, from the lowest: compounds 1, 2 and 3 (each within the scatter of the next, the first and the last beyond it). At a limit, below all of these: compound 4.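

In this assay, 4-(trifluoromethoxy)phenyl on this aromatic carbon, ortho to two ethoxy groups, gives an at least 440-fold lower number from compound 3 to compound 4 (2.64 log units; beyond the scatter) in place of fluoro and an at least 210-fold lower number from compound 1 to compound 4 (2.33 log units; beyond the scatter) in place of chloro. Among these compounds, the halogen swap gave only a 2.1-fold higher number from compound 1 to compound 3 (0.31 log units; beyond the scatter), so the earlier compounds gave no sign of a change this large at this position. The reading for compound 4 is a limit and not a number, so the full size of both steps stays unknown: the limit of < 1 ug/mL in this assay, at which 1 of the 4 values shown sits.

Open, going by these compounds, is whether the drop goes with the added aromatic ring itself or with the trifluoromethoxy group on it. A phenyl ring carrying an amine or a carboxylic acid instead of trifluoromethoxy, or a small methoxy group on this carbon, would bear on that question.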